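A few compounds are considered here, and "the series" means these few. Any claim that something is new, unique, unknown or untested is made for them only; others in the source may bear on it.

Three compounds built on a shared core have numbers in a functional assay on HL-60 cells (Homo sapiens) for antiproliferative activity, read by MTT assay, with a stated time of 72 h; on this read-out higher numbers stand for weaker inhibition and lower numbers for stronger inhibition. Compound 1 `COc1cc(C(=O)c2sc3ccccc3c2-c2ccccc2)cc(OC)c1OC` gives 1700 nM, compound 2 `COc1ccccc1-c1c(C(=O)c2cc(OC)c(OC)c(OC)c2)sc2ccccc12` gives 2900 nM, and compound 3 `COc1cc(C(=O)c2sc3ccccc3c2Nc2ccccc2)cc(OC)c1OC` gives 5200 nM. Two steps place that last value. There is a 3.1-fold higher number from compound 1 to compound 3 (0.49 log units; beyond the scatter), a modest change, and there is a 1.8-fold higher number from compound 2 to compound 3 (0.25 log units; within the scatter), so those two compounds cannot be told apart.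

Compound 4 `CCOc1ccc(Nc2c(C(=O)c3cc(OC)c(OC)c(OC)c3)sc3ccccc23)cc1` is the next structure to consider. It carries ethoxy in place of hydrogen on an aromatic carbon, para to a large group, which turns anilino into (4-ethoxyphenyl)amino: ethoxy in place of hydrogen on an aromatic carbon.

Going by the values given here, no measured step adds ethoxy. The closest comparison is methoxy in place of hydrogen on an aromatic carbon, which gives a 1.7-fold higher number from compound 1 to compound 2 (0.23 log units; within the scatter), a step within the scatter. It is only a loose guide, since that group sits on a phenyl, not an anilino, and in the position shown by the name 2-methoxyphenyl. One step is thin evidence, so a wide range is needed. Going by these compounds, no change beyond the scatter is therefore expected in this assay, and the direction remains open. The estimated change is a 1.3-fold lower number from compound 3 to compound 4 (0.11 log units; within the scatter). For compound 4 the expected value is 4000 nM, within an estimated range of 500 nM to 10000 nM.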

Compound 4, half-maximal inhibitory concentration: 500 nM
Compound 4: the middle estimate sits 8.0-fold (0.90 log units) above what was measured; the range from low to high includes it.
By their numbers in this assay, from the lowest: compound 4; then compounds 1, 2 and 3 (each within the scatter of the next, the first and the last beyond it).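

In this assay, going by these compounds alone, ethoxy on an aromatic carbon of the anilino ring, para to a large group, gives a 10-fold lower number from compound 3 to compound 4 (1.02 log units; beyond the scatter) and so shows that this position can respond strongly to a small added chain, whereas the one earlier added group, methoxy on the phenyl ring of compound 2, left a step within the scatter. The gain also reaches past the other two compounds, with a 5.8-fold lower number from compound 2 to compound 4 (0.76 log units; beyond the scatter) and a 3.4-fold lower number from compound 1 to compound 4 (0.53 log units; beyond the scatter), which makes compound 4 the most potent of the four, even though the bare anilino of compound 3 stood above compound 1 by a 3.1-fold higher number from compound 1 to compound 3 (0.49 log units; beyond the scatter) before ethoxy was added. Nothing shown here explains why one added ethoxy changes the number this much.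

The compounds shown leave open whether the step belongs to ethoxy itself, since methoxy, a longer chain such as propoxy, or an amine at this same place would separate the effect of the oxygen from that of the chain. They also leave open whether ethoxy elsewhere on the ring, or on the phenyl ring of compound 1, would give a step of similar size.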